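Swapping a chlorophenyl for a hydroxyphenyl on a urea

A few compounds are considered here, and "the series" means these few. Any claim that something is new, unique, unknown or untested is made for them only; others in the source may bear on it.

Compound 3 `Cc1cc(NC(=O)Nc2cccc(Cl)c2)c2ccccc2n1` gives 21000 nM in an ADME assay on HEK293 cells (Homo sapiens) for cytotoxicity, with a stated time of 72 h; a lower number here means that less compound is needed, a higher number that more compound is needed for the effect. Going by the values given here, it is the only compound here with a number rather than a limit. Compound 1 `COc1ccc(NC(=O)Nc2cc(C)nc3ccccc23)cc1` reaches only the limit > 25000 nM in this assay. Compound 2 `Cc1cc(NC(=O)Nc2ncccc2C)c2ccccc2n1` likewise reaches only the limit > 25000 nM in this assay. Compound 3 thus stands just under the point where the other two sit, namely (the limit of > 25000 nM in this assay, at which 2 of the 3 values shown sit). Among the compounds with values here, the single measured step, an at least 1.1-fold lower number from compound 2 to compound 3 (0.07 log units; that floor lies within the scatter), exchanged one aryl group for another on an amide-type nitrogen and lies within the scatter.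

Compound 4 `Cc1cc(NC(=O)Nc2ccc(O)cc2)c2ccccc2n1` differs from compound 3 as follows: 4-hydroxyphenyl in place of 3-chlorophenyl on an amide-type nitrogen. This is again an aryl-for-aryl exchange at the same nitrogen, and the measured step of that kind moved nothing beyond the scatter. Within the data shown here, no measured step involves a hydroxyphenyl. A step within the scatter, or a return to the limit, is therefore expected. Compound 4 is expected to give about 28000 nM in this assay, with a range from 14000 nM to 60000 nM. The expected step is a 1.3-fold higher number from compound 3 to compound 4 (0.12 log units; within the scatter).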

Compound 4, half-maximal effective concentration: > 25000 nM
Compound 4: only a limit was reported; the forecaster's own chance of this, stated with the estimate: 60%; the middle value is on the limit's open side.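

In this assay, placing a 4-hydroxyphenyl on this amide-type nitrogen, with a hydrogen-bond donor and acceptor that the 3-chlorophenyl lacks, gives an at least 1.1-fold higher number from compound 3 to compound 4 (0.07 log units; that floor lies within the scatter) and so shows no change beyond the scatter. The other two steps to compound 4, from compound 1 and compound 2, cannot be read, since both ends of each are limits. Going by these compounds alone, compound 3 remains the only compound with a number rather than a limit, and the other values now gather at a single point: the limit of > 25000 nM in this assay, at which 3 of the 4 values shown sit.

On these data alone, how far past the limit compound 4 lies stays open, as does the size of any difference among the three compounds at the limit. Also open, as far as these compounds go, is whether an amine or a carboxylic acid on the phenyl ring, or a longer chain in place of the aryl group, would give a number clearly under that limit.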